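Acylamino chain variation in the sulfonate series

A few compounds are considered here, and "the series" means these few. Any claim that something is new, unique, unknown or untested is made for them only; others in the source may bear on it.

Measured compounds in a functional assay on M21 cells (Homo sapiens) for antiproliferative activity, read by sulforhodamine B assay, with a stated time of 48 h; on this read-out lower numbers stand for stronger inhibition and higher numbers for weaker inhibition:
compound 1 `CC(=O)Nc1cccc(S(=O)(=O)Oc2ccccc2C(C)C)c1` gives 31000 nM
compound 2 `CCC(=O)Nc1cccc(S(=O)(=O)Oc2ccccc2C(C)C)c1` gives 25000 nM
compound 3 `CCCCCC(=O)Nc1cccc(S(=O)(=O)Oc2ccccc2C(C)C)c1` gives 11000 nM

Compound 3 holds the lowest number of the three, and both its gaps to the others are beyond the scatter. The steps behind it are small: a 1.2-fold lower number from compound 1 to compound 2 (0.09 log units; within the scatter) stays within the scatter, while a 2.8-fold lower number from compound 1 to compound 3 (0.45 log units; beyond the scatter) and a 2.3-fold lower number from compound 2 to compound 3 (0.36 log units; beyond the scatter) are modest. Lengthening the chain on the carbonyl carbon has so far gone with lower numbers, with no compound against this among the three.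

Compound 4 `CC(C)c1ccccc1OS(=O)(=O)c1cccc(NC(=O)C(C)(C)C)c1` differs from compound 3 by tert-butyl in place of pentyl on a carbonyl carbon. For the measured compounds named here, the change shortens the chain by one carbon and branches it, which no measured step covers directly. The modest size of the chain steps suggests any shift in this assay will be small, most likely a somewhat higher number than compound 3, possibly within the scatter. For compound 4 the expected value in this assay is 16000 nM (range 7000 nM to 35000 nM), which is an expected step of a 1.5-fold higher number from compound 3 to compound 4 (0.16 log units; within the scatter).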

Compound 4, half-maximal inhibitory concentration: 13000 nM
Estimate against measurement, compound 4: 1.2-fold (0.09 log units) above; the measured number falls inside the stated range.
By their numbers in this assay, from the lowest: compounds 3, 4, 2 and 1 (each within the scatter of the next, the first and the last beyond it).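

In this assay tert-butyl on the carbonyl carbon does about as well as pentyl: a 1.2-fold higher number from compound 3 to compound 4 (0.07 log units; within the scatter) lies within the scatter, so a long unbranched chain is not required to reach the low end of this small set. Against the shorter groups the result is split, since a 2.4-fold lower number from compound 1 to compound 4 (0.38 log units; beyond the scatter) is beyond the scatter and modest, while a 1.9-fold lower number from compound 2 to compound 4 (0.28 log units; within the scatter) stays within it, which separates tert-butyl from methyl but not from ethyl. Nothing available explains these steps.

Still open, as far as these compounds go, is whether a chain longer than pentyl, a cyclohexyl ring or a terminal carboxylic acid or amine on the carbonyl carbon would give a clear separation from compound 3. Also open, from the compounds shown here alone, is whether the shared core responds to the same acyl groups in the same way once its isopropyl group is replaced.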